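Acyl Variation and Cytotoxicity in Hepatoma Cells

The source may report more compounds than this note shows. Statements on the series, on what has been measured and on what is new or still open speak of the compounds shown alone.

The measured compounds:
compound 1, `CC(=O)OCC(=O)OCCc1c(-c2ccccc2Cl)c2cc(Cl)ccc2[nH]c1=O`, 100000 nM
compound 2, `O=C(OCCc1c(-c2ccccc2Cl)c2cc(Cl)ccc2[nH]c1=O)C1CCCC1`, 46000 nM

Both compounds share one core and differ only in the group on the carbonyl carbon. In an ADME assay on HepG2 2.2.15 cells (Homo sapiens) for cytotoxicity (a lower number here means that less compound is tolerated, a higher number that more compound is tolerated), compound 1 gives 100000 nM, and compound 2 gives 46000 nM. Within the data shown here, the one measured step, a 2.2-fold lower number from compound 1 to compound 2 (0.34 log units; beyond the scatter), is modest but beyond the scatter, and it leaves compound 2 as the lower of the two numbers in this assay, with compound 1 as its only neighbour.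

Compound 3 `O=C(CCOc1ccccc1)OCCc1c(-c2ccccc2Cl)c2cc(Cl)ccc2[nH]c1=O` takes the same step one place further: 2-phenoxyethyl in place of cyclopentyl on a carbonyl carbon. Among the measured compounds shown here, the only measured step that bears on it is a 2.2-fold lower number from compound 1 to compound 2 (0.34 log units; beyond the scatter), which also changed the group on the carbonyl carbon and lowered the number modestly. That step shows the core tolerates a change at this position without large movement, so for compound 3 a step of at most modest size is expected in this assay, most likely downward or none beyond the scatter, a 1.5-fold lower number from compound 2 to compound 3 (0.19 log units; within the scatter). Compound 3 is therefore estimated at 30000 nM, with a range from 12000 nM to 80000 nM.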

Compound 3, half-maximal cytotoxic concentration: 46000 nM
Compound 3: the middle estimate sits 1.5-fold (0.19 log units) below what was measured; low and high end bracket the measured number.
By their numbers in this assay, from the lowest: compounds 2 and 3 (each within the scatter of the next); then compound 1.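

In this assay, putting 2-phenoxyethyl in place of cyclopentyl on the carbonyl carbon gives no change at the digits printed from compound 2 to compound 3 (within the scatter), so this position takes an aromatic ring and an ether oxygen, with 9 heavy atoms entering where 5 leave, and the number does not move beyond the scatter. The comparison with compound 1 reads the same way as it did for compound 2: phenoxymethyl in place of acetoxy on a saturated chain carbon bound to a carbonyl carbon gives a 2.2-fold lower number from compound 1 to compound 3 (0.34 log units; beyond the scatter), so two quite different groups, one with a non-aromatic ring and one with an aromatic ring, end within the scatter of each other, and compound 1 alone stands apart from them. Nothing shown here gives a reason for this grouping.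

The compounds shown leave open whether an amine, a carboxylic acid or a longer chain on this carbonyl carbon would move the number further than these groups do. They also leave open how these acyl groups behave in any read-out other than this assay.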